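The source may hold more compounds than are shown below. What is called first, only, known or untested is meant among the compounds shown, and "the series" means these compounds.

Measured in a functional assay on MKN-45 cells (Homo sapiens) for cytotoxicity, read by MTT assay, with a stated time of 72 h; a higher number here means a weaker inhibitor, a lower number a stronger inhibitor:

Compound 1, `CN(C)CCNc1nc(-c2ccc(NC(=O)Nc3ccccc3)cc2)nc2ccsc12`, gives 1120 nM.
Compound 2, `CN(C)CCNc1nc(-c2ccc(NC(=O)Nc3ccc(F)cc3)cc2)nc2ccsc12`, gives 330 nM.
Compound 3, `CCN(CC)CCCNc1nc(-c2ccc(NC(=O)Nc3ccccc3)cc2)nc2c(Cl)c(Cl)sc12`, gives 1640 nM.

Compounds 1 and 2 share one core; compound 3 has a different one, and the difference between the two cores is not broken down here. Compounds 1 and 2 differ only in the change (fluoro in place of hydrogen on an aromatic carbon), and in this assay this change made a step of a 3.4-fold lower number from compound 1 to compound 2 (0.53 log units; beyond the scatter). Compound 3 and compound 1 give numbers that lie within the usual scatter of each other, so no order between them can be read. Compound 2 and compound 3 lie further apart, with compound 2 showing the lower number.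

Compound 4, `CCN(CC)CCCNc1nc(-c2ccc(NC(=O)Nc3ccc(F)cc3)cc2)nc2c(Cl)c(Cl)sc12`, is not yet measured. Going by the values given here, it differs from compound 3 by the change (fluoro in place of hydrogen on an aromatic carbon), which is the same change as the one from compound 1 to compound 2, at the same kind of place. Among the compounds with values here, the expectation for compound 4 therefore rests on the one earlier step: because a 3.4-fold lower number from compound 1 to compound 2 (0.53 log units; beyond the scatter) was seen on the core of compound 1, a similar step is expected on the core of compound 3, and compound 4 is estimated at a 3.0-fold lower number from compound 3 to compound 4 (0.47 log units; beyond the scatter). Starting from compound 3, this means compound 4 is expected to give about 550 nM in this assay, most likely between 250 nM and 1200 nM.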

Compound 4, half-maximal inhibitory concentration: 1700 nM
Compound 4: the middle estimate sits 3.1-fold (0.49 log units) below what was measured; measured number outside the range, above it.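

In this assay, the fluoro in place of hydrogen on the core of compound 3 gave a 1.0-fold higher number from compound 3 to compound 4 (0.02 log units; within the scatter), so on this core the change has no effect that can be read, whereas it had a clear effect on the core of compound 1. The size of a step seen on one core therefore did not carry over to the other core in this series, and the gap between the two steps is larger than the scatter alone would explain: the same change on two cores in this assay, a 3.4-fold lower number (0.53 log units; beyond the scatter) from compound 1 to compound 2 and a 1.0-fold higher number (0.02 log units; within the scatter) from compound 3 to compound 4, 3.5-fold (0.55 log units) apart, beyond the scatter of two such steps

Going by these compounds alone, this does not show why the two cores respond differently, nor which part of the difference between them matters, since that difference is not broken down and each core contributes only one pair of compounds. It also gives no general rule for this change across the series, only a warning that a step measured on one core is a weak guide to the step on another.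

The compounds shown leave open whether a different group in the place of the fluoro, such as methoxy or trifluoromethyl, would also behave differently on the two cores. They also leave open how the change would behave on a core with the amine chain of compound 1 and the ring substituents of compound 3, which would help separate the two parts of the core difference.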